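Allyloxy to propoxy on the bromo-bearing amide

The compounds below may be only part of what the source reports. "The series", "measured", "known", "first", "only" and "open" are said of these compounds alone.

Compound 2 `C=CCOc1ccc(C(=O)Nc2cccc(Br)n2)cc1` gives the highest number of the two measured in an in vitro assay on HEK-tsA201 cells for antagonist activity at Neuronal acetylcholine receptor; alpha4/beta2 (Homo sapiens), read by fluorescence and calcium flux (a higher number here means a weaker inhibitor, a lower number a stronger inhibitor), at 70100 nM. Compound 1 `CCCOc1ccc(C(=O)Nc2cccc(C)n2)cc1` gives 7500 nM in this assay, a gap beyond the scatter. Compound 3 `CCCOc1ccc(C(=O)Nc2cccc(Br)n2)cc1` differs from compound 2 by ethyl in place of vinyl on a saturated chain carbon bound to an oxygen on an aromatic ring. For the measured compounds named here, no measured pair isolates this change, so its size is not known from the series. A move toward a lower number is expected, a 2.3-fold lower number from compound 2 to compound 3 (0.37 log units; beyond the scatter), though with wide uncertainty. Compound 3 is estimated at 30000 nM in this assay, within 8000 nM to 100000 nM.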

Compound 3, half-maximal inhibitory concentration: 80700 nM
The estimate for compound 3 lay 2.7-fold (0.43 log units) below the measured number, within the range that was stated.
By their numbers in this assay, from the lowest: compound 1; then compounds 2 and 3 (each within the scatter of the next).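

Ethyl in place of vinyl on a saturated chain carbon bound to an oxygen on an aromatic ring gives a 1.2-fold higher number from compound 2 to compound 3 (0.06 log units; within the scatter) in this assay and so leaves the number unaffected by the double bond outside aromatic rings in this pair. Bromo in place of methyl on an aromatic carbon, with propoxy held constant, gives an 11-fold higher number from compound 1 to compound 3 (1.03 log units; beyond the scatter) as the first single-place step read beyond the scatter. No available evidence accounts for either step.

As far as these compounds go, a longer chain such as butoxy remains open at the chain position. Also open, from the compounds shown here alone, is whether chloro or an amine on that aromatic carbon would track with methyl or with bromo.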